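From dimethylamino to morpholin-4-yl on a carbonyl carbon

The source may report more compounds than this note shows. Statements on the series, on what has been measured and on what is new or still open speak of the compounds shown alone.

Values measured so far in a physicochemical assay for solubility (a higher number here means a more soluble compound, a lower number a less soluble compound), for three compounds
Compound 1 `CC(C)C(=O)N1CCC[C@H]1C(=O)N1CCC(NS(=O)(=O)c2cc(S(=O)(=O)c3ccccc3)ccc2C(F)(F)F)CC1` gives 100000 nM
Compound 2 `CN(C)CC(=O)N1CCC[C@H]1C(=O)N1CCC(NS(=O)(=O)c2cc(S(=O)(=O)c3ccccc3)ccc2C(F)(F)F)CC1` gives 100000 nM
Compound 3 `CN(C)C(=O)N1CCC[C@H]1C(=O)N1CCC(NS(=O)(=O)c2cc(S(=O)(=O)c3ccccc3)ccc2C(F)(F)F)CC1` gives 100000 nM

Compound 3 stands level with compounds 1 and 2 at the digits shown, so the three measured compounds cannot be told apart on these numbers. The next structure is compound 4 `O=C([C@@H]1CCCN1C(=O)N1CCOCC1)N1CCC(NS(=O)(=O)c2cc(S(=O)(=O)c3ccccc3)ccc2C(F)(F)F)CC1` which has not yet been measured. It keeps the core of compound 3 and carries morpholin-4-yl in place of dimethylamino on a carbonyl carbon with nothing else altered.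

Within the data shown here, three measured steps bear on this change, all at that same carbonyl carbon. Dimethylamino in place of isopropyl gave no change at the digits printed from compound 1 to compound 3 (within the scatter) and dimethylamino in place of (dimethylamino)methyl gave no change at the digits printed from compound 2 to compound 3 (within the scatter) while (dimethylamino)methyl in place of isopropyl gave no change at the digits printed from compound 1 to compound 2 (within the scatter) as well. Among the measured compounds shown here, none of the measured compounds holds morpholin-4-yl, so this evidence is indirect. Resting on no change at the digits printed from compound 1 to compound 3 (within the scatter) and the two other steps, no step beyond the scatter is expected in this assay in either direction. The expected step is no change at the digits printed from compound 3 to compound 4 (within the scatter) on this estimate. Compound 4 is estimated at 100000 nM with an expected range from 50000 nM to 120000 nM in this measurement.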

Compound 4, solubility: 50000 nM
Beside the measured number, compound 4's estimate is 2.0-fold (0.30 log units) above it; low and high end bracket the measured number.
By their numbers in this assay, from the lowest: compounds 4, 1, 2 and 3 (each within the scatter of the next).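

Placing morpholin-4-yl in place of dimethylamino on a carbonyl carbon gives a 2.0-fold lower number from compound 3 to compound 4 (0.30 log units; within the scatter) in this assay, and the same position reads a 2.0-fold lower number from compound 2 to compound 4 (0.30 log units; within the scatter) against (dimethylamino)methyl and a 2.0-fold lower number from compound 1 to compound 4 (0.30 log units; within the scatter) against isopropyl. The earlier compounds shown here showed this position only with groups that hold no ring, whereas compound 4 carries a six-membered non-aromatic ring with a hydrogen-bond acceptor there, and all three of its steps still stay within the scatter. Nothing measured here speaks to what lies behind this result.

From the compounds shown here alone, whether a carboxylic acid, a piperazine ring or a longer alkyl chain on this carbonyl carbon would give a step beyond the scatter stays open. All four compounds differ only at this one place, and what a change elsewhere on the shared core would do in this assay is open as well.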